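Cyclopropyl to thiophen-3-yl on a carbonyl carbon

A few compounds are considered here, and "the series" means these few. Any claim that something is new, unique, unknown or untested is made for them only; others in the source may bear on it.

Among the measured compounds shown here, in a functional assay on A2780 cells (Homo sapiens) for antiproliferative activity, read by fluorescence, with a stated time of 72 h (on this read-out higher numbers stand for weaker inhibition and lower numbers for stronger inhibition), compound 1 (`CN1CCC(C(=O)N2Cc3c(NC(=O)C4CC4)n[nH]c3C2(C)C)CC1`) gives 1420 nM and stands highest of the two numbers so far. Compound 2 (`CC1(C)c2[nH]nc(NC(=O)c3ccc(F)cc3)c2CN1C(=O)C1CCN(C2CC2)CC1`) gives 380 nM as the lower number, a gap beyond the scatter. Compound 3 (`CN1CCC(C(=O)N2Cc3c(NC(=O)c4ccsc4)n[nH]c3C2(C)C)CC1`) keeps the core of compound 1 and carries thiophen-3-yl in place of cyclopropyl on a carbonyl carbon. For the measured compounds named here, no measured pair isolates this change, so the size of the step in this assay remains a judgement. A modest move toward a lower number is expected, near the edge of the scatter. Going by the values given here, the only pointer is compound 2 at 380 nM as evidence that numbers lower than that of compound 1 occur. The estimate means a 2.0-fold lower number from compound 1 to compound 3 (0.31 log units; beyond the scatter) as the expected step. Compound 3 is expected at 700 nM within an estimated range of 250 nM to 1800 nM for now.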

Compound 3, half-maximal inhibitory concentration: 140 nM
Compound 3: the middle estimate sits 5.0-fold (0.70 log units) above what was measured, and the stated range ends above it.
By their numbers in this assay, from the lowest: compound 3; then compound 2; then compound 1.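

In this assay, thiophen-3-yl in place of cyclopropyl on a carbonyl carbon gives a 10-fold lower number from compound 1 to compound 3 (1.01 log units; beyond the scatter), a large step. Among the compounds shown here, this is the first single-place comparison, and it shows that the group on this carbonyl carbon can strongly shift the antiproliferative read-out while the rest of the structure stays fixed. No measurement shown gives a reason for the size of this step.

For the compounds shown here, the single pair cannot separate the contributions of ring size, aromatic character and the sulfur atom, since all three change together. A phenyl or cyclopentyl group on the same carbonyl carbon would help separate them, and the compounds shown leave open how either would compare with thiophen-3-yl.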